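The compounds below may be only part of what the source reports. "The series", "measured", "known", "first", "only" and "open" are said of these compounds alone.

Of the compounds shown here, two of a shared core have been tested in a functional assay on HCT-116 cells (Homo sapiens) for cytotoxicity, read by sulforhodamine B assay, with a stated time of 48 h, tested at 100 nM; on this read-out lower numbers stand for a stronger effect and higher numbers for a weaker effect at the one concentration tested. Compound 1 `COc1cc(C)cc(-c2nn(CC#N)cc2-c2ccc(-c3cccc(C(C)=O)c3)nc2)c1` gives 78% in this assay. Going by the values given here, compound 2 `Cc1cc(O)cc(-c2nn(CC#N)cc2-c2ccnc(-c3ccc(Oc4ccccc4)cc3)c2)c1` gives 86% in this assay; this number and the one for compound 1 lie within the usual scatter of each other, so the two stand together. Compound 3 `Cc1cc(O)cc(-c2nn(CC#N)cc2-c2ccnc(-c3ccc(N(C)C)cc3)c2)c1` is not yet measured. It differs from compound 2 in one place: dimethylamino in place of phenoxy on an aromatic carbon. Among the compounds with values here, no measured pair shows what such a change does here, so the step is expected to stay within the scatter, with a number 4 percentage points lower from compound 2 to compound 3 (within the scatter) as its estimated size. Compound 3 is therefore expected to give about 82% in this assay, most likely between 60% and 100%.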

Compound 3, a percentage reported as activity, at one concentration (the size of the read-out at that concentration, not a potency): 87%
Compound 3: middle estimate off by 5 percentage points, on the low side, within the range that was stated.
By their numbers in this assay, from the lowest: compounds 1, 2 and 3 (each within the scatter of the next).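

In this assay, putting dimethylamino in place of phenoxy on an aromatic carbon, para to a large group, gives a number 1 percentage points higher from compound 2 to compound 3 (within the scatter). A phenoxy group with its ring and a smaller dimethylamino group without a ring therefore stand together here, so this change in size and ring content leaves the read-out within the scatter. No measurement on hand explains this result.

As far as these compounds go, whether a carboxylic acid or a primary amine in this place would move the read-out beyond the scatter remains open. So does the effect of a longer chain, such as a butoxy group.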